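Morpholine in Place of Piperidine on the Thiocarbonyl Carbon

This account rests on a few compounds, and the source may have more. Where it says the series, first, only, none or still open, it means among the compounds named here.

Measured so far:
Compound 1, `Cc1cccc(/C(N)=N/NC(=S)N2CCCCC2)n1`, gives 39% in a functional assay on MCF7 cells (Homo sapiens) for cytotoxicity, read by MTT assay, with a stated time of 72 h, tested at 10 uM; on this read-out higher numbers stand for more inhibition of growth at the one concentration tested and lower numbers for less inhibition of growth.
Compound 2, `N/C(=N\NC(=S)N1CCN(c2ccccn2)CC1)c1ccc(F)cn1`, gives 35.8% in this assay.

Compound 1 holds the higher of the two numbers, and compound 2 stands a little lower, but the gap between them lies within the scatter of repeated measurements, so the two cannot be put in order. The two measured compounds differ from each other in more than one place, so no single structural change can be tied to a change in this assay from what has been measured.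

Compound 3, `Cc1cccc(/C(N)=N/NC(=S)N2CCOCC2)n1`, is the next compound, and it differs from compound 1 in one place only: morpholin-4-yl in place of piperidin-1-yl on a thiocarbonyl carbon. For the measured compounds named here, no measured pair shows this kind of change, so there is nothing to support a step in either direction. The step from compound 1 to compound 3 in this assay is therefore expected to be a number 5 percentage points lower from compound 1 to compound 3 (within the scatter), that is, nothing beyond the scatter. For compound 3 the expected value in this assay is 34%, with a range from 18% to 50%.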

Compound 3, percent growth inhibition at one concentration: 39.1%
For compound 3 the middle estimate is 5.1 percentage points below the measured one, and the stated range covers the measured number.
By their numbers in this assay, from the lowest: compounds 2, 1 and 3 (each within the scatter of the next).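

For the compounds shown here, this is the first single-place change, and it shows that on a thiocarbonyl carbon of the core of compound 1, morpholin-4-yl in place of piperidin-1-yl gives a number 0.1 percentage points higher from compound 1 to compound 3 (within the scatter) in this assay as its result. The entering group brings a ring oxygen and a hydrogen-bond acceptor that piperidin-1-yl lacks, yet this exchange leaves the two compounds indistinguishable at the one concentration tested, so this position accepts either six-membered ring without a change that can be read in this read-out. No measurement at hand explains this outcome.

What remains open is whether the position stays as undemanding for a group of another kind, such as an open-chain dimethylamino group or a 4-methylpiperazin-1-yl ring, both of which lie outside the compounds shown. Going by these compounds, it is also open whether the same exchange would give a similar result on the core of compound 2, which differs from compound 1 in more than one place, or at concentrations other than the single one used here.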